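The source may hold more compounds than are shown below. What is called first, only, known or untested is meant among the compounds shown, and "the series" means these compounds.

Measured in a functional assay on HepG2 cells (Homo sapiens) for cytotoxicity, read by MTT assay, with a stated time of 48 h; a higher number here means a weaker inhibitor, a lower number a stronger inhibitor:

- compound 2 `Clc1ccnc2cc(OCc3ccccc3)ccc12`: 2680 nM
- compound 3 `CCOc1ccc2c(Cl)ccnc2c1`: 2660 nM
- compound 1 `CN(C)CCNc1ccnc2cc(OCc3ccc(F)cc3)ccc12`: 790 nM

Among these three numbers, compound 2 gives the highest one. Going by the values given here, its nearest neighbour is compound 3, and the one step between them, a 1.0-fold lower number from compound 2 to compound 3 (0.00 log units; within the scatter), changes nothing beyond the scatter. The furthest is compound 1, whose number sits well below that of compound 2, but compound 1 differs from compound 2 in two places at once, so its value alone cannot be tied to either change.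

The compound still to be measured is compound 4 `Fc1ccc(COc2ccc3c(Cl)ccnc3c2)cc1`. It differs from compound 2 by fluoro in place of hydrogen on an aromatic carbon. Among the compounds with values here, no measured step here changes a single substituent on that outer ring; the one measured step, from compound 2 to compound 3, replaces the whole ring with a methyl and still stays within the scatter, which suggests that this part of the molecule is not where the number moves much. A single fluorine added there is therefore expected to give, at most, a small step in this assay, with no clear direction.

The expected number for compound 4 is 2300 nM, within a range of 1000 nM to 5500 nM, which means an estimated step of a 1.2-fold lower number from compound 2 to compound 4 (0.07 log units; within the scatter).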

Compound 4, half-maximal inhibitory concentration: 3010 nM
Compound 4: middle estimate off by 1.3-fold (0.12 log units), on the low side, and the stated range covers the measured number.
By their numbers in this assay, from the lowest: compound 1; then compounds 3, 2 and 4 (each within the scatter of the next).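

In this assay, fluoro in place of hydrogen on an aromatic carbon of a six-membered aromatic ring of carbon only, para to a large group, gives a 1.1-fold higher number from compound 2 to compound 4 (0.05 log units; within the scatter) and so stays within the scatter, which makes this the first direct test of a single small substituent on that ring and shows no measurable effect on the number. Compound 4 also opens a one-place comparison at a different part of the molecule, since chloro in place of (2-(dimethylamino)ethyl)amino on an aromatic carbon gives a 3.8-fold higher number from compound 1 to compound 4 (0.58 log units; beyond the scatter) and is the only new step that lies beyond the scatter, so among these compounds that aromatic carbon is where the number moves. No measured evidence accompanies these compounds to explain either result.

As far as these compounds go, whether a plain amine or a longer chain at that aromatic carbon would shift the number as far as the (2-(dimethylamino)ethyl)amino group remains open. From the compounds shown here alone, it is also open whether a larger group on the fluoro carbon, such as a carboxylic acid or a nitrile, would move the number at all.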